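The compounds below may be only part of what the source reports. "The series", "measured", "known", "first", "only" and "open" are said of these compounds alone.

Compound 3 `CC(=O)Nc1ccc(-n2nncc2CN2C(=O)C3(C(C#N)=C(N)Oc4c(N)cc5nc6ccccc6nc5c43)c3ccccc32)cc1` is one of three closely related compounds examined in a functional assay on HCT-116 cells (Homo sapiens) for antiproliferative activity, read by MTT assay, with a stated time of 48 h; a lower number here means a stronger inhibitor, a higher number a weaker inhibitor. In this assay compound 3 gives > 50000 nM, which is a limit of the assay and not a number. Compound 1 `N#CC1=C(N)Oc2c(c3nc4ccccc4nc3c3ccccc23)C12C(=O)N(Cc1cnnn1-c1ccccc1Br)c1ccccc12` in this assay gives > 50000 nM, again a limit. Compound 2 `COc1ccc(-n2nncc2CN2C(=O)C3(C(C#N)=C(N)Oc4c3c3nc5ccccc5nc3c3ccccc43)c3ccccc32)cc1` in this assay gives > 50000 nM, also a limit. The step that the two limits leave unreadable from compound 1 to compound 2 is therefore of unreadable size because of the limit of > 50000 nM in this assay, at which 3 of the 3 values shown sit.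

Compound 4 `N#CC1=C(N)Oc2c(N)cc3nc4ccccc4nc3c2C12C(=O)N(Cc1cnnn1-c1ccc([N+](=O)[O-])cc1[N+](=O)[O-])c1ccccc12` differs from compound 3 in one place: 2,4-dinitrophenyl in place of 4-acetamidophenyl on an aromatic nitrogen. Compound 3 thus stands at the limit, as do the other two compounds shown. For the measured compounds named here, the only step measured, a change on an aromatic nitrogen from compound 1 to compound 2, left both values at the limit, so no step of readable size bears on the change at hand. With every value in the series at the limit, compound 4 is expected to remain in this assay at about 50000 nM, within a range from 20000 nM to 200000 nM. The expected step of a number no higher from compound 3 to compound 4 (the limit leaves the size open) is accordingly estimated as none beyond the scatter.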

Compound 4, half-maximal inhibitory concentration: 23900 nM
Compound 4: the middle estimate sits 2.1-fold (0.32 log units) above what was measured; low and high end bracket the measured number.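

In this assay, replacing 4-acetamidophenyl with 2,4-dinitrophenyl gives an at least 2.0-fold lower number from compound 3 to compound 4 (0.32 log units; beyond the scatter), the only readable step among the compounds shown. This shows that a change at this position, on an aromatic nitrogen of a five-membered aromatic ring with 3 nitrogen, can bring a member of the series within the measurable range, which the swap of 2-bromophenyl for 4-methoxyphenyl could not show. The true size of the step remains open, and the step from compound 1 to compound 2 still cannot be read: the limit of > 50000 nM in this assay, at which 3 of the 4 values shown sit.

This single pair cannot separate the loss of the acetamide from the entry of the two nitro groups. From the compounds shown here alone, whether one nitro group alone, an amine or a carboxylic acid on the same phenyl would give a similar number remains open, as does the effect of 2,4-dinitrophenyl on the core of compound 1.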